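Taking the Ring-Bearing Group Off Compound 2

A few compounds are considered here, and "the series" means these few. Any claim that something is new, unique, unknown or untested is made for them only; others in the source may bear on it.

In a physicochemical assay for metabolic stability, read by LC-MS, in phosphate buffer, with a stated time of 120 min, at pH 7.4, tested at 1 uM (a higher number here means that more of the compound is left, a lower number that less of the compound is left), compound 2 `CC#CCn1c(N2CCC[C@@H](N)C2)nc2c1c(=O)n(Cc1ccc(Cl)cc1C(=O)OCc1oc(=O)oc1C)c(=O)n2C` gives 12%, level within the scatter with compound 3 `CC#CCn1c(N2CCC[C@@H](N)C2)nc2c1c(=O)n(Cc1ccc(Br)cc1C(=O)OCc1oc(=O)oc1C)c(=O)n2C` at 8.32% and far under compound 1 `CC#CCn1c(N2CCC[C@@H](N)C2)nc2c1c(=O)n(Cc1ccc(Br)cc1C(=O)OC)c(=O)n2C` at 99.4%. Compound 4 `CC#CCn1c(N2CCC[C@@H](N)C2)nc2c1c(=O)n(Cc1ccc(Cl)cc1C(=O)O)c(=O)n2C` follows from compound 2 by one change: a hydrogen atom in place of a group of 8 heavy atoms (5 carbon, 3 oxygen; one five-membered aromatic ring with 2 hetero atoms), on an oxygen next to a carbonyl group. The closest evidence is a number 91.1 percentage points lower from compound 1 to compound 3 (beyond the scatter), a large step that brings in a similar five-membered aromatic ring. The other measured step, a number 3.7 percentage points lower from compound 2 to compound 3 (within the scatter), stays within the scatter, so the exchange of bromo for chloro tells little here. Compound 4 also lacks that ring, so a large upward step is expected, a number 84 percentage points higher from compound 2 to compound 4 (beyond the scatter). For compound 4 the estimated value is 96%, with an expected range from 82% to 105%.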

Compound 4, percent of the compound remaining: 101%
Beside the measured number, compound 4's estimate is 5 percentage points below it; measured number inside the range.
By their numbers in this assay, from the lowest: compounds 3 and 2 (each within the scatter of the next); then compounds 1 and 4 (each within the scatter of the next).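

In this assay, a hydrogen atom in place of the ring-bearing group, on an oxygen next to a carbonyl group, gives a number 89 percentage points higher from compound 2 to compound 4 (beyond the scatter). The earlier compounds shown here showed that group only as an addition, and this step shows the same large size when it leaves. The 2-carboxy-4-chlorophenyl in place of 4-bromo-2-(methoxycarbonyl)phenyl gives a number 1.6 percentage points higher from compound 1 to compound 4 (within the scatter), so that exchange separates nothing here. Nothing given here explains the size of the step. On these data alone, whether an amide or an ethyl ester at this carbonyl would stay level with compound 4 or approach compound 2 remains open.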